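The source may hold more compounds than are shown below. What is called first, only, known or untested is meant among the compounds shown, and "the series" means these compounds.

Compound 1 `COc1cc(N(C)CCN(C)C)c(NC(=O)c2ccnc(Cl)c2)cc1Nc1nccc(-c2cn(C)c3ccccc23)n1` and compound 2 `COc1cc(N(C)CCN(C)C)c(NC(=O)c2ccnc(Cl)c2)cc1Nc1nccc(-c2cn(CCCO)c3ccccc23)n1` share one core and differ only at a saturated chain carbon bound to an aromatic nitrogen. In a functional assay on A549 cells (Homo sapiens) for antiproliferative activity, read by MTT assay, with a stated time of 72 h (a higher number here means a weaker inhibitor, a lower number a stronger inhibitor), compound 1 gives 970 nM, and in this assay compound 2 gives 2140 nM. For the measured compounds named here, the one measured step, a 2.2-fold higher number from compound 1 to compound 2 (0.34 log units; beyond the scatter), is modest but beyond the scatter. Compound 2 therefore stands with the higher of the two numbers, the nearest neighbour being compound 1.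

Compound 3 `COc1cc(N(C)CCN(C)C)c(NC(=O)c2ccncn2)cc1Nc1nccc(-c2cn(CCCO)c3ccccc23)n1` keeps the 2-hydroxyethyl chain of compound 2 and alters a different site: pyrimidin-4-yl in place of 2-chloropyridin-4-yl on a carbonyl carbon. Going by the values given here, no measured pair bears on this change; the step of a 2.2-fold higher number from compound 1 to compound 2 (0.34 log units; beyond the scatter) concerns a different site and gives no guide to an exchange on the carbonyl carbon. In the absence of any such precedent, no step beyond the scatter is expected in this assay, and the uncertainty is correspondingly wide. Compound 3 is estimated at 2000 nM, with a range from 600 nM to 6500 nM. This estimate corresponds to an expected step of a 1.1-fold lower number from compound 2 to compound 3 (0.03 log units; within the scatter).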

Compound 3, half-maximal inhibitory concentration: 2660 nM
Compound 3: middle estimate off by 1.3-fold (0.12 log units), on the low side, within the range that was stated.
By their numbers in this assay, from the lowest: compound 1; then compounds 2 and 3 (each within the scatter of the next).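

In this assay, for the compounds shown here, the exchange on the carbonyl carbon, pyrimidin-4-yl in place of 2-chloropyridin-4-yl, gives a 1.2-fold higher number from compound 2 to compound 3 (0.09 log units; within the scatter), so with the chain of compound 2 held fixed, removing the chlorine and adding a second ring nitrogen produces no step that can be told from the scatter. Going by these compounds alone, the earlier pair had varied only the group on the aromatic nitrogen, so this is the first reading at the carbonyl site, and it applies to this one exchange on this one chain, not to the site in general. Nothing measured here offers a reason for this result.

The compounds shown leave open whether a phenyl ring, or a pyridine ring carrying an amine or a carboxylic acid, would give a step beyond the scatter when placed on the carbonyl carbon. They also leave open whether pyrimidin-4-yl would read the same alongside the group that compound 1 carries on the aromatic nitrogen, or alongside a longer chain ending in an amine.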